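The source may hold more compounds than are shown below. What is called first, only, known or untested is meant among the compounds shown, and "the series" means these compounds.

Compound 2 `O=[N+]([O-])c1ccc(NC(CO)CO)c([N+](=O)[O-])c1` stands at a limit: in a functional assay on MCF7 cells (Homo sapiens) for cytotoxicity (a higher number here means a weaker inhibitor, a lower number a stronger inhibitor), compound 2 gives > 100000 nM, which is a limit of the assay rather than a number. Compound 1 `O=[N+]([O-])c1ccccc1NC(CO)CO` gives > 100000 nM in this assay, again a limit. Compound 3 `O=[N+]([O-])c1cc(C(F)(F)F)ccc1NC(CO)CO` gives > 100000 nM in this assay, also a limit. Compound 4 `O=[N+]([O-])c1ccc(NC(CO)CO)c(C(F)(F)F)c1` is not yet measured and differs from compound 2 by trifluoromethyl in place of nitro on an aromatic carbon. The same kind of change was measured as a step that the two limits leave unreadable from compound 2 to compound 3, and the related changes a step that the two limits leave unreadable from compound 1 to compound 2 and a step that the two limits leave unreadable from compound 1 to compound 3 are equally unreadable because of the limit of > 100000 nM in this assay, at which 3 of the 3 values shown sit. No step beyond the scatter can therefore be expected in either direction. Compound 4 is expected to give about 150000 nM, between 50000 nM and 500000 nM, most likely once more a limit. The expected step is a step that the limit leaves unreadable from compound 2 to compound 4.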

Compound 4, half-maximal inhibitory concentration: 88300 nM
Compound 4: middle estimate off by 1.7-fold (0.23 log units), on the high side; the measured number falls inside the stated range.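

For the compounds shown here, with trifluoromethyl in place of nitro on the aromatic carbon ortho to the (2-hydroxy-1-(hydroxymethyl)ethyl)amino group, compound 4 is the first compound here to give a true number, not a limit, in this assay. The change reads as an at least 1.1-fold lower number from compound 2 to compound 4 (0.05 log units; that floor lies within the scatter). So this swap at this position can bring the read-out within measurable range, though how large the step really is cannot be told: the limit of > 100000 nM in this assay, at which 3 of the 4 values shown sit.

From the compounds shown here alone, whether an amine or a carboxylic acid at this same position would give a clearly lower number stays open.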